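This account rests on a few compounds, and the source may have more. Where it says the series, first, only, none or still open, it means among the compounds named here.

Three compounds built on one shared core, each carrying a urea that joins the core to a fluorine-bearing phenyl ring, were tested in an ADME assay on HepG2 cells (Homo sapiens) for cytotoxicity, with a stated time of 72 h; on this read-out lower numbers stand for an effect already at smaller amounts and higher numbers for an effect only at larger amounts of compound. Compound 2 `Cc1cc(NC(=O)Nc2cccc(F)c2)c2ccccc2n1` reaches only a limit of that assay, > 25000 nM, and not a number. Compound 1 `Cc1cc(NC(=O)Nc2ccc(F)c(F)c2)c2ccccc2n1` gives 21000 nM in this assay. Compound 3 `Cc1cc(NC(=O)Nc2cc(F)ccc2F)c2ccccc2n1` likewise ends at a limit, > 25000 nM. Compound 2 therefore stands at the edge of what this assay can report, alongside one further value, as the limit of > 25000 nM in this assay, at which 2 of the 3 values shown sit, shows. The two steps that touch compound 2 both concern a fluoro on an aromatic carbon: an at least 1.1-fold higher number from compound 1 to compound 2 (0.07 log units; that floor lies within the scatter), and a step that the two limits leave unreadable from compound 2 to compound 3. Neither gives a readable size, and nothing in the set reaches beyond the usual scatter.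

Compound 4 `Cc1cc(NC(=O)Nc2cccc(Cl)c2)c2ccccc2n1` differs from compound 2 by chloro in place of fluoro on an aromatic carbon. Going by the values given here, the only steps that bear on this change are the two above, and both leave the effect of swapping a halogen unresolved, so no step beyond the scatter is expected in this assay; the expected change is a step that the limit leaves unreadable from compound 2 to compound 4. Compound 4 is thus estimated at 30000 nM in this assay, with a range from 15000 nM to 80000 nM, most likely again reported only as a limit.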

Compound 4, half-maximal effective concentration: 19000 nM
The estimate for compound 4 lay 1.6-fold (0.20 log units) above the measured number; measured number inside the range.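

Going by these compounds alone, this is the first comparison in the set of one halogen swapped for another. At this place, on an aromatic carbon meta to a large group, chloro gives a readable number in this assay, whereas fluoro gave only an assay limit. The swap reads as an at least 1.3-fold lower number from compound 2 to compound 4 (0.11 log units; that floor lies within the scatter), so the data hint at a lower number with chloro but do not establish a real change. Its true size stays hidden because one end of the step is a limit and not a number: the limit of > 25000 nM in this assay, at which 2 of the 4 values shown sit.

The compounds shown leave open whether a larger halogen such as bromo, or a non-halogen group such as methyl, methoxy or an amine, would move the number further in the same direction at this place. They also leave open whether chloro would act the same way elsewhere on the phenyl ring, or alongside a second halogen, since the only chloro shown here sits at this one place and alone on its ring.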